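The source may hold more compounds than are shown below. What is called first, only, known or untested is meant among the compounds shown, and "the series" means these compounds.

In a physicochemical assay for solubility (a lower number here means a less soluble compound, a higher number a more soluble compound), three compounds that share one core have been measured. Compound 1 `O=C(c1ccccn1)N1CCC(NS(=O)(=O)c2cc(S(=O)(=O)c3ccccc3)ccc2C(F)(F)F)CC1` gives 100000 nM. Compound 3 `CC(C)(O)CCN1CCC(NS(=O)(=O)c2cc(S(=O)(=O)c3ccccc3)ccc2C(F)(F)F)CC1` gives 50000 nM, which is within the scatter of compound 1. Compound 2 `O=S(=O)(NC1CCN(S(=O)(=O)c2ccccc2)CC1)c1cc(S(=O)(=O)c2ccccc2)ccc1C(F)(F)F` gives 25000 nM, so compound 1 stands clearly apart from compound 2 only.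

Compound 4 `CC(C)(C)OC(=O)N1CC[C@H](C(=O)N2CCC(NS(=O)(=O)c3cc(S(=O)(=O)c4ccccc4)ccc3C(F)(F)F)CC2)C1` has not yet been measured. On a carbonyl carbon whose other neighbours are an amide-type nitrogen in a ring, it carries 1-(tert-butoxycarbonyl)pyrrolidin-3-yl in place of pyridin-2-yl on a carbonyl carbon.

For the measured compounds named here, no measured step makes this exact change. The closest evidence comes from two steps that replace the whole (pyridin-2-yl)carbonyl on the amine nitrogen in a ring. One is a 4.0-fold lower number from compound 1 to compound 2 (0.60 log units; beyond the scatter), and the other is a 2.0-fold lower number from compound 1 to compound 3 (0.30 log units; within the scatter). Both run towards a lower number, but only the first lies beyond the scatter, and neither keeps the carbonyl, so they offer only loose guidance. Compounds 2 and 3 themselves differ within the scatter, as a 2.0-fold higher number from compound 2 to compound 3 (0.30 log units; within the scatter) shows.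

A modest move towards a lower number is therefore expected, an estimated 2.5-fold lower number from compound 1 to compound 4 (0.40 log units; beyond the scatter). Compound 4 is estimated at 40000 nM, with an expected range from 12000 nM to 100000 nM.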

Compound 4, solubility: 25000 nM
For compound 4 the middle estimate is 1.6-fold (0.20 log units) above the measured one; the range from low to high includes it.
By their numbers in this assay, from the lowest: compounds 2, 4, 3 and 1 (each within the scatter of the next, the first and the last beyond it).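

For the compounds shown here, until now the only changes at this position replaced the whole (pyridin-2-yl)carbonyl on the amine nitrogen in a ring, so the carbonyl itself never stayed in place. Compound 4 keeps that carbonyl and changes only the group on it, and in this assay this gives a 4.0-fold lower number from compound 1 to compound 4 (0.60 log units; beyond the scatter), so keeping the carbonyl on the amide-type nitrogen in a ring does not by itself hold the number at that of compound 1. Nothing among the data accounts for this step.

The entering 1-(tert-butoxycarbonyl)pyrrolidin-3-yl differs from pyridin-2-yl in several ways at once, so the compounds shown leave open whether the step follows from the loss of pyridin-2-yl, from the five-membered non-aromatic ring, from the tert-butoxycarbonyl or from the defined stereocentre. A free pyrrolidin-3-yl amine, the opposite stereoisomer of compound 4, or a simple phenyl or cyclopentyl on the same carbonyl carbon would separate these parts, and a carboxylic acid on the ring would extend the comparison further.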